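Swapping a dichloropyridine for a chlorophenyl in weak activators

This account rests on a few compounds, and the source may have more. Where it says the series, first, only, none or still open, it means among the compounds named here.

compound 1, `Cc1cc(C(=O)O)ccc1CN1CCC[C@H](O[C@H](CO)c2cc(Cl)nc(Cl)c2)[C@@H]1c1ccccc1`: > 200000 nM
compound 2, `Cc1cc(C(=O)O)ccc1CN1CC[C@H](OC(CO)c2cc(Cl)cc(Cl)c2)[C@@H]1c1ccccc1`: 185000 nM

Both measured compounds were tested in an assay on isolated protein for activation of cGMP-dependent protein kinase 1 (Homo sapiens), read by ADP-Glo, with stated times of 30 min and 2 h; a lower number here means that less compound is needed, a higher number that more compound is needed for the effect. For compound 1 the result is a limit of the assay, > 200000 nM, not a number. Compound 2 gives 185000 nM in this assay. The two results sit close together at the weak end of the range, one of them at the edge of what the assay reports (the limit of > 200000 nM in this assay, at which 1 of the 2 values shown sits).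

Compound 3, `Cc1cc(C(=O)O)ccc1CN1CCC[C@H](O[C@H](CO)c2cccc(Cl)c2)[C@@H]1c1ccccc1`, has not yet been measured. It differs from compound 1 in one place: 3-chlorophenyl in place of 2,6-dichloropyridin-4-yl on a saturated chain carbon bound to an oxygen on a saturated carbon and a saturated chain carbon. For the measured compounds named here, as compound 1 stands only at a limit, no measured step is available to guide the expectation, and no change beyond the usual scatter is expected in this assay. The estimate for compound 3 is 200000 nM, with a range from 80000 nM to 500000 nM. This corresponds to an expected step of a number no higher from compound 1 to compound 3 (the limit leaves the size open).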

Compound 3, half-maximal effective concentration: 93000 nM
For compound 3 the middle estimate is 2.2-fold (0.33 log units) above the measured one; low and high end bracket the measured number.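

In this assay, 3-chlorophenyl in place of 2,6-dichloropyridin-4-yl gives an at least 2.1-fold lower number from compound 1 to compound 3 (0.33 log units; beyond the scatter) on the shared core, the first readable sign that the result responds to the aromatic group at this position. Even so, compound 3 at 93000 nM remains a weak activator. From the compounds shown here alone, the full size of the step stays open because compound 1 stands at a limit of the assay and not at a number: the limit of > 200000 nM in this assay, at which 1 of the 3 values shown sits.

The change alters the ring nitrogen and the chlorine substitution together, leaving it open which of the two accounts for the step. Going by these compounds, it is also open how an unsubstituted phenyl, a 3-methoxyphenyl or a 3-aminophenyl would read at this place.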